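Swapping Imidazole for Benzimidazole on a Triphenyl Chain

A few compounds are considered here, and "the series" means these few. Any claim that something is new, unique, unknown or untested is made for them only; others in the source may bear on it.

Compound 1 `c1ccc(C(CCn2ccnc2)(c2ccccc2)c2ccccc2)cc1` carries an imidazole ring at the end of a short chain that ends in three aromatic rings. In an assay for inhibition of Aromatase (Homo sapiens), using microsomes, tested at 500 nM (a higher number here means more inhibition at the concentration tested (going by the name of the read-out), a lower number less inhibition), compound 1 gives 38%, the highest of the two numbers shown. Compound 3 `c1ccc(-c2cc(Cn3ccnc3)cc(-c3ccccc3)c2)cc1` gives 12% in this assay, a number below that of compound 1 by more than the usual scatter. Compound 2 `c1ccc(-c2cccc(Cn3cnc4ccccc43)c2)cc1` is reported in this assay as "not active" (no number reported), with no number attached; it carries a benzimidazole, but on a different scaffold, so it cannot be set directly against compound 1.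

Compound 4 `c1ccc(C(CCn2cnc3ccccc32)(c2ccccc2)c2ccccc2)cc1` is the unmeasured partner of compound 1. The difference between them is 1H-benzimidazol-1-yl in place of 1H-imidazol-1-yl on a saturated chain carbon, three bonds along the chain from three aromatic carbons. Among the compounds with values here, no measured pair in this set shows that change on the same scaffold, so its effect is unknown here. Compound 4 is expected to give about 26% in this assay, within a range from 6% to 48%. That estimate means an expected step of a number 12 percentage points lower from compound 1 to compound 4 (beyond the scatter) downward, somewhat beyond the scatter.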

Compound 4, a percentage reported as inhibition, at one concentration (the size of the read-out at that concentration, not a potency): "not active" (no number reported)
The entry for compound 4 holds no number, and the estimate cannot be compared.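

Within the data shown here, compound 4 is reported in this assay only as "not active", without a number, so no step from compound 1 to it can be read. Nothing shown here explains this result. From the compounds shown here alone, the size of any effect of exchanging 1H-imidazol-1-yl for 1H-benzimidazol-1-yl remains open.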